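Branching the Sulfonyl Chain on the Weakest Agonist

The source may hold more compounds than are shown below. What is called first, only, known or untested is meant among the compounds shown, and "the series" means these compounds.

Compound 3 `CCS(=O)(=O)N1CCC(Oc2ncnc3c2CCN3c2ccc(S(C)(=O)=O)cc2F)CC1` stands highest of the three measured compounds in a functional assay on CHO-K1 cells for agonist activity at Glucose-dependent insulinotropic receptor (Homo sapiens), read by a luciferase reporter, with a stated time of 5 h (a higher number here means that more compound is needed for the effect, a lower number that less compound is needed), with 1580 nM. Compound 1 `CC(C)OC(=O)N1CCC(Oc2ncnc3c2CCN3c2ccc(S(C)(=O)=O)cc2F)CC1` gives 50.1 nM, and compound 2 `CCCOC(=O)N1CCC(Oc2ncnc3c2CCN3c2ccc(S(C)(=O)=O)cc2F)CC1` gives 79.4 nM. The steps of a 32-fold higher number from compound 1 to compound 3 (1.50 log units; beyond the scatter) and a 20-fold higher number from compound 2 to compound 3 (1.30 log units; beyond the scatter) were large, whereas the step of a 1.6-fold higher number from compound 1 to compound 2 (0.20 log units; within the scatter) stayed within the scatter. Compound 4 `CC(C)S(=O)(=O)N1CCC(Oc2ncnc3c2CCN3c2ccc(S(C)(=O)=O)cc2F)CC1` differs from compound 3 by methyl in place of hydrogen on a saturated chain carbon bound to a saturated chain carbon and a sulfonyl sulfur; seen one bond further out, this reads ethylsulfonyl to isopropylsulfonyl. Among the measured compounds shown here, the only measured step that resembles this chain reshaping, a 1.6-fold higher number from compound 1 to compound 2 (0.20 log units; within the scatter), was small, so the step of a 1.1-fold lower number from compound 3 to compound 4 (0.05 log units; within the scatter) is expected to remain within the scatter. For compound 4 the estimated value in this assay is 1400 nM, within 600 nM to 3500 nM.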

Compound 4, half-maximal effective concentration: 1260 nM
The estimate for compound 4 lay 1.1-fold (0.05 log units) above the measured number, within the range that was stated.
By their numbers in this assay, from the lowest: compounds 1 and 2 (each within the scatter of the next); then compounds 4 and 3 (each within the scatter of the next).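

Branching the sulfonyl chain does not bring back agonist activity in this assay: ethylsulfonyl to isopropylsulfonyl stays within the scatter (a 1.3-fold lower number from compound 3 to compound 4 (0.10 log units; within the scatter)). The isopropylsulfonyl group leaves compound 4 as far from the carbonyl-linked compounds as the ethylsulfonyl group left compound 3 (a 16-fold higher number from compound 2 to compound 4 (1.20 log units; beyond the scatter); a 25-fold higher number from compound 1 to compound 4 (1.40 log units; beyond the scatter)). Among these compounds, then, swapping the carbonyl-linked group for a sulfonyl group on the ring nitrogen matters far more than the shape of the sulfonyl chain. No measurement here explains the large sulfonyl steps. Going by these compounds, whether a longer chain such as butylsulfonyl or a ring such as cyclopropylsulfonyl would behave the same remains open.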